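A few compounds are considered here, and "the series" means these few. Any claim that something is new, unique, unknown or untested is made for them only; others in the source may bear on it.

Measured in an ADME assay for permeability, using PAMPA, at pH 7.4; a lower number here means that the compound crosses the layer more slowly, a higher number that the compound crosses the layer faster
compound 1 `CN(C[C@H]1Cc2c(cccc2N2CCN(C3COC3)CC2)CN1)[C@H]1CCCc2cccnc21` gives 725 nm/s
compound 2 `CN(C[C@H]1Cc2c(cccc2N2CCN3CCC[C@H]3C2)CN1)[C@H]1CCCc2cccnc21` gives 167 nm/s
compound 3 `CN(C[C@H]1Cc2c(cccc2N2CCN(c3cccc(C(F)(F)F)c3)CC2)CN1)[C@H]1CCCc2cccnc21` gives 141 nm/s
compound 4 `CN1CCN(c2cccc3c2C[C@H](CN(C)[C@H]2CCCc4cccnc42)NC3)CC1` is not yet measured

Compound 3 sits with compound 2 at the low end of these numbers, the two lying within the scatter of each other. Compound 1 stands clearly apart from both.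

The next change is methyl in place of 3-(trifluoromethyl)phenyl on an amine nitrogen in a ring. For the measured compounds named here, no measured pair shows this swap directly. The nearest evidence is a 5.1-fold lower number from compound 1 to compound 3 (0.71 log units; beyond the scatter) and a 4.3-fold lower number from compound 1 to compound 2 (0.64 log units; beyond the scatter) (both modest and alike in size). Two different replacements of the oxetan-3-yl group of compound 1 therefore land at about the same level. Going by the values given here, compound 4 also lacks that group, so it is expected to stay at that level rather than approach compound 1, though this rests on only two steps.

The expected result is a 1.4-fold higher number from compound 3 to compound 4 (0.15 log units; within the scatter) (no step beyond the scatter). For compound 4 the estimated value is 200 nm/s (90 nm/s to 450 nm/s).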

Compound 4, apparent permeability: 996 nm/s
The estimate for compound 4 lay 5.0-fold (0.70 log units) below the measured number; measured number above the stated range.
By their numbers in this assay, from the lowest: compounds 3 and 2 (each within the scatter of the next); then compounds 1 and 4 (each within the scatter of the next).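

In this assay, the ring-nitrogen substituent now splits the series into two levels, and losing the oxetan-3-yl group does not by itself bring the number down: methyl and oxetan-3-yl cannot be told apart (a 1.4-fold higher number from compound 1 to compound 4 (0.14 log units; within the scatter)). The low level of compound 3 therefore belongs to the 3-(trifluoromethyl)phenyl group rather than to the absence of oxetan-3-yl (a 7.1-fold higher number from compound 3 to compound 4 (0.85 log units; beyond the scatter)), and the fused bicyclic group of compound 2 also stands clearly lower than the methyl-bearing ring of compound 4 (a 6.0-fold higher number from compound 2 to compound 4 (0.78 log units; beyond the scatter)). No measurement at hand explains this split.

Still open, from the compounds shown here alone, is whether ethyl, isopropyl or acetyl on the same nitrogen stays at the level of compound 4. It is also unclear whether an unsubstituted phenyl falls to the level of compound 3.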